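Aniline halogen swaps on a shared core

The source may report more compounds than this note shows. Statements on the series, on what has been measured and on what is new or still open speak of the compounds shown alone.

Measured so far in a functional assay on OVCAR-4 cells (Homo sapiens) for inhibition, read by sulforhodamine B assay, with a stated time of 48 h; on this read-out lower numbers stand for stronger inhibition of growth and higher numbers for weaker inhibition of growth:
Compound 1 `CN1CCN(CCCOc2cccc3nc(Nc4ccc(Cl)c(C(F)(F)F)c4)ccc23)CC1`: 2730 nM
Compound 2 `CN1CCN(CCCOc2cccc3nc(Nc4ccc(Cl)c(F)c4)ccc23)CC1`: 3130 nM
Compound 3 `CN1CCN(CCCOc2cccc3nc(Nc4ccc(F)c(F)c4)ccc23)CC1`: 6420 nM

Compound 3 stands highest of the three numbers: the steps of a 2.1-fold higher number from compound 2 to compound 3 (0.31 log units; beyond the scatter) and a 2.4-fold higher number from compound 1 to compound 3 (0.37 log units; beyond the scatter) both lie beyond the scatter, whereas a 1.1-fold higher number from compound 1 to compound 2 (0.06 log units; within the scatter) does not. Compound 4 `CN1CCN(CCCOc2cccc3nc(Nc4cc(Cl)cc(Cl)c4)ccc23)CC1` has not yet been measured. Its change from compound 3 is 3,5-dichlorophenyl in place of 3,4-difluorophenyl on a nitrogen on an aromatic ring. Going by the values given here, the step of a 2.1-fold higher number from compound 2 to compound 3 (0.31 log units; beyond the scatter) bears on it most directly, a single fluoro in place of chloro having raised the number modestly; compound 4 reverses that exchange at both halogen sites of the ring, though the substitution pattern also shifts, and no measured pair shows that shift on its own. A modest downward step in this assay is therefore expected, roughly undoing the earlier change, which as an estimate means a 2.1-fold lower number from compound 3 to compound 4 (0.33 log units; beyond the scatter). Compound 4 is expected to give 3000 nM, with a range of 1200 nM to 7500 nM.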

Compound 4, concentration for 50% growth inhibition: 2550 nM
For compound 4 the middle estimate is 1.2-fold (0.07 log units) above the measured one, within the range that was stated.
By their numbers in this assay, from the lowest: compounds 4, 1 and 2 (each within the scatter of the next); then compound 3.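

In this assay, 3,5-dichlorophenyl in place of 3,4-difluorophenyl on the nitrogen gives a 2.5-fold lower number from compound 3 to compound 4 (0.40 log units; beyond the scatter), so exchanging both fluorines for chlorines, with the pattern also changed, moves the number down by a modest step. Against the two chlorine-bearing rings already measured, a 1.2-fold lower number from compound 2 to compound 4 (0.09 log units; within the scatter) and a 1.1-fold lower number from compound 1 to compound 4 (0.03 log units; within the scatter) both stay within the scatter, so compounds 1, 2 and 4 sit at one level, and compound 3, the only ring shown without chlorine, stands apart from all three. No supporting evidence bears on this result.

Going by these compounds alone, the fluoro-to-chloro exchange and the shift in substitution pattern remain unseparated, as no pair here changes the pattern alone. On these data alone, whether a ring carrying methoxy or nitrile in place of halogen stays at this level also remains open.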